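This account rests on a few compounds, and the source may have more. Where it says the series, first, only, none or still open, it means among the compounds named here.

Compound 1 `Cc1nc(C)c(C(=O)Oc2ccc(/C=C/C(=O)O)cc2O)nc1C` gives 271%.
Compound 2 `CCOC(=O)/C=C/c1ccccc1OC(=O)c1nc(C)c(C)nc1C` gives 17.8%.
Compound 3 `CCOC(=O)/C=C/c1ccc(OC(=O)c2nc(C)c(C)nc2C)c(O)c1` gives 207%.

In a functional assay on EA.hy 926 cells (Homo sapiens) for cytotoxicity, read by MTT assay, with stated times of 24 h and 12 h, tested at 25 uM (a lower number here means a weaker effect, a higher number a stronger effect of the compound at the concentration tested), compound 3 stands second highest of the three numbers. Going by the values given here, its nearest neighbour is compound 1, and the single measured step, a number 64 percentage points lower from compound 1 to compound 3 (beyond the scatter), is large and beyond the scatter. The furthest from compound 3 is compound 2, which gives 17.8%, far lower than compound 3.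

Compound 4 `CCOC(=O)/C=C/c1ccc(OC(=O)c2nc(C)c(C)nc2C)cc1` has not yet been measured. It differs from compound 3 in one place: hydrogen in place of hydroxy on an aromatic carbon. Among the compounds with values here, no measured step covers this kind of change, since the one step that has been measured concerns ethyl in place of hydrogen on an oxygen next to a carbonyl group, not the hydroxy. Within the data shown here, compound 2 is the only measured compound without a hydroxy, but it differs from compound 3 in more than one place, so its low number is only a weak hint. On that hint a drop is expected, with wide uncertainty.

For compound 4 the estimated step is a number 87 percentage points lower from compound 3 to compound 4 (beyond the scatter). Compound 4 is therefore expected to give about 120%, between 30% and 230%.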

Compound 4, a percentage reported as activity, at one concentration (the size of the read-out at that concentration, not a potency): 58.8%
Beside the measured number, compound 4's estimate is 61.2 percentage points above it, within the range that was stated.
By their numbers in this assay, from the lowest: compound 2; then compound 4; then compound 3; then compound 1.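

Going by these compounds alone, putting hydrogen in place of hydroxy on an aromatic carbon gives the first direct reading of this position: in this assay, the change produces a number 148.2 percentage points lower from compound 3 to compound 4 (beyond the scatter), a large step. The rest of the molecule stays the same across this step, so the loss can be assigned to this single hydroxy and not to any other part of the structure. The data offer no measured explanation of how this hydroxy exerts such an effect.

As far as these compounds go, it remains open whether an amine or a methoxy group at the same position would keep the number high, as the hydroxy does, or lower it, as hydrogen does. From the compounds shown here alone, it is also open whether removing the hydroxy would produce a step of similar size in compound 1, which has no ethyl group on its acid.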